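Fluoro to Methyl on the Core of a Receptor Agonist

The source may report more compounds than this note shows. Statements on the series, on what has been measured and on what is new or still open speak of the compounds shown alone.

Compound 1 `Nc1nc(-c2ccc(F)c(C(F)(F)F)c2)cs1` gives 100 nM in a functional assay for agonist activity at thrombopoietin receptor (Homo sapiens); a higher number here means that more compound is needed for the effect, a lower number that less compound is needed. Compound 2 `Nc1nc(-c2ccc(F)c(C(F)(F)F)c2)c(F)s1` adds a fluoro on the shared core and gives 89 nM; the two numbers sit within the scatter of each other, so compound 2 stands alongside compound 1 rather than apart from it. Compound 3 `Cc1sc(N)nc1-c1ccc(F)c(C(F)(F)F)c1` alters that fluoro: methyl in place of fluoro on an aromatic carbon. Going by the values given here, the single measured step, a 1.1-fold lower number from compound 1 to compound 2 (0.05 log units; within the scatter), is the only one that bears on this change, and it was within the scatter, so no shift beyond the scatter is expected in this assay. Compound 3 is therefore estimated at 100 nM, with a range from 40 nM to 250 nM. The expected step is a 1.1-fold higher number from compound 2 to compound 3 (0.05 log units; within the scatter).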

Compound 3, half-maximal effective concentration: 180 nM
Beside the measured number, compound 3's estimate is 1.8-fold (0.26 log units) below it; low and high end bracket the measured number.
By their numbers in this assay, from the lowest: compounds 2, 1 and 3 (each within the scatter of the next, the first and the last beyond it).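

On this carbon of the shared core, next to the ring sulfur, the choice of group now registers in this assay: methyl in place of fluoro gives a 2.0-fold higher number from compound 2 to compound 3 (0.31 log units; beyond the scatter) as a modest step, whereas fluoro in place of hydrogen had stayed within the scatter. Methyl in place of hydrogen gives a 1.8-fold higher number from compound 1 to compound 3 (0.26 log units; within the scatter) and so does not set compound 3 apart from compound 1. Nothing measured here explains the gap between fluoro and methyl. From the compounds shown here alone, whether chloro, ethyl, an amine or a nitrile on this carbon would raise or lower the number remains open.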